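A few compounds are considered here, and "the series" means these few. Any claim that something is new, unique, unknown or untested is made for them only; others in the source may bear on it.

Measured so far:
compound 1, `CCCCNc1ccnc2cc(Cl)ccc12`: 8450 nM
compound 2, `CCCCNc1ccnc2cc(F)ccc12`: 1980 nM

Going by the values given here, in a functional assay on MCF7 cells (Homo sapiens) for cytotoxicity, read by sulforhodamine B assay, with a stated time of 48 h (a higher number here means a weaker inhibitor of growth, a lower number a stronger inhibitor of growth), compound 1 gives 8450 nM, the highest of the two numbers so far. Among the compounds with values here, its nearest neighbour is compound 2, which in this assay gives 1980 nM; the only measured step is a 4.3-fold lower number from compound 1 to compound 2 (0.63 log units; beyond the scatter), fluoro in place of chloro on an aromatic carbon, and it lies beyond the scatter.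

Compound 3, `CN(C)CCNc1ccnc2cc(Cl)ccc12`, keeps the chloro of compound 1 and alters the chain instead: dimethylamino in place of ethyl on a saturated chain carbon, two bonds along the chain from a nitrogen on an aromatic ring. Within the data shown here, no measured step touches the chain; the one step in hand, from compound 1 to compound 2, concerns the aromatic halogen only and gives no guide to the chain change. The expectation for this assay therefore rests on compound 1 alone, with no direction beyond the scatter to be read from the numbers shown.

Compound 3 is estimated at 6000 nM in this assay, with a range of 1500 nM to 25000 nM, which corresponds to an expected step of a 1.4-fold lower number from compound 1 to compound 3 (0.15 log units; within the scatter).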

Compound 3, concentration for 50% growth inhibition: 15400 nM
Compound 3: middle estimate off by 2.6-fold (0.41 log units), on the low side; the range from low to high includes it.
By their numbers in this assay, from the lowest: compound 2; then compounds 1 and 3 (each within the scatter of the next).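

In this assay the chain position now has its first reading, a 1.8-fold higher number from compound 1 to compound 3 (0.26 log units; within the scatter) for dimethylamino in place of ethyl on a saturated chain carbon, two bonds along the chain from a nitrogen on an aromatic ring. On this single pair, the chain accepts a group that brings nitrogen and a hydrogen-bond acceptor in place of all-carbon ethyl without a shift that can be claimed, whereas the earlier halogen exchange, a 4.3-fold lower number from compound 1 to compound 2 (0.63 log units; beyond the scatter) at the aromatic carbon, lies beyond the scatter. No measurement shown bears on why the chain exchange reads as it does.

Since compound 3 is the only member shown with the dimethylamino chain and it carries chloro, whether the same exchange would read alike with the fluoro of compound 2 remains open. Also open, as far as these compounds go, is how far this tolerance extends to other chain ends and lengths, such as a diethylamino group, a pyrrolidine, a hydroxyl or a longer chain ending in dimethylamino.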